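Replacing the 4-fluorophenyl group of compound 2

The source may hold more compounds than are shown below. What is called first, only, known or untested is meant among the compounds shown, and "the series" means these compounds.

Values measured in a functional assay on NCI-H460 cells (Homo sapiens) for antiproliferative activity, read by MTT assay, with a stated time of 48 h (on this read-out higher numbers stand for weaker inhibition and lower numbers for stronger inhibition), are
- compound 1 `Cc1ccc(Nc2ccc3c(c2)C(O)(Cc2ccccc2)C(=O)N3)cc1` with 31600 nM
- compound 2 `O=C1Nc2ccc(Nc3ccc(F)cc3)cc2C1(O)Cc1ccccc1` with 18100 nM
- compound 3 `O=C1Nc2ccc(Nc3ccc(C(F)(F)F)cc3)cc2C1(O)Cc1ccccc1` with 9100 nM

Compound 2 lies within the scatter of both other compounds (a 1.7-fold lower number from compound 1 to compound 2 (0.24 log units; within the scatter)) and (a 2.0-fold lower number from compound 2 to compound 3 (0.30 log units; within the scatter)). Compound 4 `O=C1Nc2ccc(Nc3ccccc3Cl)cc2C1(O)Cc1ccccc1` has 2-chlorophenyl in place of 4-fluorophenyl on a nitrogen on an aromatic ring. Within the data shown here, the only step beyond the scatter is modest (a 3.5-fold lower number from compound 1 to compound 3 (0.54 log units; beyond the scatter)). All three measured steps swap one group on an aromatic carbon, and none brings in a 2-chlorophenyl. In this assay no step beyond the scatter is therefore expected in either direction, and the estimated step is small (a 1.2-fold lower number from compound 2 to compound 4 (0.08 log units; within the scatter)). Compound 4 is estimated at 15000 nM (expected range 6000 nM to 37000 nM).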

Compound 4, half-maximal inhibitory concentration: 14600 nM
The estimate for compound 4 lay 1.0-fold (0.01 log units) above the measured number; measured number inside the range.
By their numbers in this assay, from the lowest: compounds 3, 4, 2 and 1 (each within the scatter of the next, the first and the last beyond it).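

In this assay, the 2-chlorophenyl group brings a different halogen and a different ring position to the nitrogen, yet the step stays small (a 1.2-fold lower number from compound 2 to compound 4 (0.09 log units; within the scatter)). Set against the 4-methylphenyl group, it gives a modest step beyond the scatter (a 2.2-fold lower number from compound 1 to compound 4 (0.34 log units; beyond the scatter)), so trifluoromethyl is no longer the only change to do so. No available evidence explains these steps. Still open, from the compounds shown here alone, is how 4-chlorophenyl would compare with 2-chlorophenyl, which would separate ring position from the choice of halogen. Also open, going by these compounds, is how a phenyl ring carrying an amine or a carboxylic acid would behave here.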